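The compounds below may be only part of what the source reports. "The series", "measured", "known", "first", "only" and "open" are said of these compounds alone.

Measured so far:
compound 1, `COc1cccc(Nc2nccc(-c3ccncc3)n2)c1`, with 400 nM in a functional assay for inhibition, with Homo sapiens as the target; a lower number here means a stronger inhibitor, a higher number a weaker inhibitor
compound 2, `CC(=O)Nc1cccc(Nc2nccc(-c3ccccn3)n2)c1`, with 300 nM in this assay

Compound 2 carries the smaller of the two numbers in this assay, but compound 1 lies within the scatter of it, so the two cannot be told apart on these data. Compound 3, `CC(=O)Nc1cccc(Nc2nccc(-c3ccncc3)n2)c1`, has not yet been measured. It differs from compound 2 in one place: pyridin-4-yl in place of pyridin-2-yl on an aromatic carbon. Among the measured compounds shown here, no pair of measured compounds isolates this exchange, and the only other compound that carries pyridin-4-yl, compound 1, also bears a different group elsewhere; its value and that of compound 2 sit within the scatter of one another. The step from compound 2 to compound 3 in this assay is therefore expected to be a 1.2-fold higher number from compound 2 to compound 3 (0.07 log units; within the scatter), none beyond the scatter. Compound 3 is accordingly estimated at 350 nM, within a range of 120 nM to 1000 nM.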

Compound 3, half-maximal inhibitory concentration: 2700 nM
Estimate against measurement, compound 3: 7.7-fold (0.89 log units) below, outside the stated range (above it).
By their numbers in this assay, from the lowest: compounds 2 and 1 (each within the scatter of the next); then compound 3.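

The exchange of pyridin-2-yl for pyridin-4-yl on an aromatic carbon of the six-membered aromatic ring with 2 nitrogen keeps the same atoms and the same counts, yet in this assay it gives a 9.0-fold higher number from compound 2 to compound 3 (0.95 log units; beyond the scatter), so this place is sensitive to where the nitrogen stands in the attached ring. With pyridin-4-yl held constant, acetamido in place of methoxy gives a 6.8-fold higher number from compound 1 to compound 3 (0.83 log units; beyond the scatter), showing that the other place matters as well, which the two earlier compounds could not show, as they differ in two places. Nothing available here accounts for either step.

From the compounds shown here alone, whether pyridin-2-yl keeps its advantage when methoxy replaces acetamido remains open. So does how pyridin-3-yl or a plain phenyl ring would fare at this place.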